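A Second Fluorine on the Aryl Ketone of Compound 1

A few compounds are considered here, and "the series" means these few. Any claim that something is new, unique, unknown or untested is made for them only; others in the source may bear on it.

compound 1 `COc1cc(-c2nnc3n2NC(c2ccco2)C(C(=O)c2ccccc2F)S3)cc(OC)c1OC`: > 100000 nM
compound 2 `COc1cc(-c2nnc3n2NC(c2ccco2)C(C(=O)c2cccc4ccccc24)S3)cc(OC)c1OC`: 33900 nM
compound 3 `COc1ccc(C(=O)C2Sc3nnc(-c4cc(OC)c(OC)c(OC)c4)n3NC2c2ccco2)cc1`: > 100000 nM

In a functional assay on HepG2 cells (Homo sapiens) for cytotoxicity, read by MTT assay, with a stated time of 48 h (on this read-out lower numbers stand for stronger inhibition and higher numbers for weaker inhibition), compound 1 gives > 100000 nM, which is a limit of the assay and not a number. Compound 3 also gives > 100000 nM, again only a limit. For the measured compounds named here, compound 2 gives 33900 nM, the one measured number here. The change of aryl ketone brings an at least 2.9-fold lower number from compound 1 to compound 2 (0.46 log units; beyond the scatter), while the step of an at least 2.9-fold higher number from compound 2 to compound 3 (0.46 log units; beyond the scatter) goes back the other way, and the step that the two limits leave unreadable from compound 1 to compound 3. Compound 1 thus sits at the limit of > 100000 nM in this assay, at which 2 of the 3 values shown sit.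

Compound 4 `COc1cc(-c2nnc3n2NC(c2ccco2)C(C(=O)c2ccc(F)c(F)c2)S3)cc(OC)c1OC` differs from compound 1 by 3,4-difluorophenyl in place of 2-fluorophenyl on a carbonyl carbon. Only the aryl-ketone steps above bear on it, and both measured changes leave the shared fluorophenyl ketone; on that basis the step that the limit leaves unreadable from compound 1 to compound 4 is expected, none beyond the scatter. Compound 4 is therefore estimated at 120000 nM, between 40000 nM and 300000 nM, most probably again reported as a limit.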

Compound 4, half-maximal inhibitory concentration: 52400 nM
Compound 4: the middle estimate sits 2.3-fold (0.36 log units) above what was measured, within the range that was stated.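

In this assay, replacing 2-fluorophenyl with 3,4-difluorophenyl on the carbonyl carbon gives an at least 1.9-fold lower number from compound 1 to compound 4 (0.28 log units; that floor lies within the scatter), and replacing 4-methoxyphenyl gives an at least 1.9-fold lower number from compound 3 to compound 4 (0.28 log units; that floor lies within the scatter). A phenyl ketone thus also yields a measured number, and the comparison with the naphthalen-1-yl ketone gives a 1.5-fold higher number from compound 2 to compound 4 (0.19 log units; within the scatter), so compound 2 and compound 4 cannot be told apart. Compound 1 and compound 3 each remain at a limit, not a number: the limit of > 100000 nM in this assay, at which 2 of the 4 values shown sit.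

The compounds shown leave open whether the number of fluorines or their placing matters. On these data alone, how an aminophenyl or a carboxyphenyl ketone would read also stays open.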